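Two benzyl swaps on a shared triazole, one measured

This account rests on a few compounds, and the source may have more. Where it says the series, first, only, none or still open, it means among the compounds named here.

The series pairs two cores that each carry a triazole bearing a benzyl group. Compound 1 `O=C1/C(=C/c2ccccc2F)CN(Cc2cn(Cc3ccccc3F)nn2)C/C1=C\c1ccccc1F` and compound 2 `O=C1/C(=C/c2ccccc2F)CN(Cc2cn(Cc3cccc(Cl)c3)nn2)C/C1=C\c1ccccc1F` share one core; compound 3 `Cc1ccc(/C=C2\CN(Cc3cn(Cc4cccc(Cl)c4)nn3)C/C(=C\c3ccc(C)cc3)C2=O)cc1` and compound 4 `Cc1ccc(/C=C2\CN(Cc3cn(Cc4ccccc4F)nn3)C/C(=C\c3ccc(C)cc3)C2=O)cc1` share the other. The difference between the two cores is not broken down here.

In a functional assay on MCF7 cells (Homo sapiens) for cytotoxicity, read by MTT assay, with a stated time of 24 h (on this read-out lower numbers stand for stronger inhibition and higher numbers for weaker inhibition), compound 1 gives 6000 nM, and compound 2 gives 12000 nM. The change between them is 2-fluorophenyl in place of 3-chlorophenyl on a saturated chain carbon bound to an aromatic nitrogen, and it made a step of a 2.0-fold lower number from compound 2 to compound 1 (0.30 log units; within the scatter). Compound 3 gives 10000 nM; against compound 2 this is within the scatter, and against compound 1 it is also within the scatter, so no order among the three is claimed.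

Compound 4 carries the same change on the other core: 2-fluorophenyl in place of 3-chlorophenyl on a saturated chain carbon bound to an aromatic nitrogen. The place is the same in words for both pairs, so this is the same change, not merely the same kind. Within the data shown here, with only one measured instance of it, and that one within the scatter, the expectation rests on compound 2 moving to compound 1 by a 2.0-fold lower number from compound 2 to compound 1 (0.30 log units; within the scatter) and on compound 3 standing at 10000 nM.

Compound 4 is expected to sit at 6000 nM, within 2500 nM to 15000 nM. The step this estimate means is a 1.7-fold lower number from compound 3 to compound 4 (0.22 log units; within the scatter), which is expected to stay within the scatter as the earlier one did.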

Compound 4, half-maximal inhibitory concentration: 28700 nM
Compound 4: middle estimate off by 4.8-fold (0.68 log units), on the low side, and the stated range ends below it.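

In this assay, the change from 3-chlorophenyl to 2-fluorophenyl, on a saturated chain carbon bound to an aromatic nitrogen, gives a 2.9-fold higher number from compound 3 to compound 4 (0.46 log units; beyond the scatter) on the second core, a modest step. Set beside the step on the first core, this shows that the change does not carry from one core to the other as a fixed step in this series: the same change on two cores in this assay, a 2.0-fold lower number (0.30 log units; within the scatter) from compound 2 to compound 1 and a 2.9-fold higher number (0.46 log units; beyond the scatter) from compound 3 to compound 4, 5.7-fold (0.76 log units) apart, beyond the scatter of two such steps

Among these compounds, the comparison rests on one pair per core, so it shows only that the same change gave different steps in these four compounds; it does not show which part of the cores goes with the difference, or whether any other benzyl change would behave the same way.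

The compounds shown leave open how an unsubstituted benzyl group, or a benzyl ring carrying a methoxy group or a nitrile, would sit on each core, and the chlorine-to-fluorine exchange cannot be read apart from the change of its place, as the two move together here. Also open, as far as these compounds go, is whether the two cores would part in the same way with an amine or a carboxylic acid on the benzyl ring.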